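Aryl hydrazone acids: whole-organism inhibition in the rat

The source may hold more compounds than are shown below. What is called first, only, known or untested is meant among the compounds shown, and "the series" means these compounds.

Measured so far:
- compound 1 `CC1CC/C(=N\Nc2ccccc2)c2ncc(C(=O)NN)c(=O)n21`: in a functional assay on the whole organism for inhibition, with Rattus norvegicus as the target (a lower number here means that less compound is needed, a higher number that more compound is needed for the effect), compound 1 gives > 1000 umol/kg, which is a limit of the assay and not a number.
- compound 2 `CC1CCC(=NNc2ccccc2)c2ncc(C(=O)O)c(=O)n21`: in this assay compound 2 gives 1.2 umol/kg.
- compound 3 `CC1CC/C(=N\Nc2ccccc2F)c2ncc(C(=O)O)c(=O)n21`: in this assay compound 3 gives > 1000 umol/kg, again a limit of the assay and not a number.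

Compound 3 therefore stands at the upper edge of what this assay can report; no number is known for it. Compound 1 sits at the same limit. Only compound 2 yields a measured dose. Within this small set, the limit of > 1000 umol/kg in this assay, at which 2 of the 3 values shown sit, is the one recurring feature, and no two measured compounds differ in a single place, so no measured step is available to anchor the next change.

The next compound, compound 4 `CC1CC/C(=N\Nc2ccc(O)cc2)c2ncc(C(=O)O)c(=O)n21`, differs from compound 3 in one place: 4-hydroxyphenyl in place of 2-fluorophenyl on an amine nitrogen.

With compound 3 known only as a limit, the step to compound 4 cannot be sized from the data; it is expected to run toward a lower dose, an at least 33-fold lower number from compound 3 to compound 4 (1.52 log units; beyond the scatter), but with a real chance that compound 4 again returns only the limit. Compound 4 is estimated at 30 umol/kg, with a range of 2 umol/kg to 1000 umol/kg.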

Compound 4, dose for 50% inhibition: > 100 umol/kg
Compound 4: only a limit was reported; the forecaster's own chance of this, stated with the estimate: 35%; at least 3.3-fold (0.52 log units) between middle value and limit.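

In this assay, compound 3 and compound 4 are both known only as limits of the assay and not as numbers, and the step between them cannot be read. The compounds shown leave open whether 4-hydroxyphenyl in place of 2-fluorophenyl on an amine nitrogen changes the dose needed at all.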